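Benzofuranyl in place of furanyl on two related cores

A few compounds are considered here, and "the series" means these few. Any claim that something is new, unique, unknown or untested is made for them only; others in the source may bear on it.

Measured compounds:
Compound 1, `COc1ncnc2c1c(-c1ccoc1)cn2[C@@H]1O[C@H](CO)[C@@H](O)[C@H]1O`: 110 nM in a functional assay on HCT-116 cells (Homo sapiens), read by MTT assay, with a stated time of 72 h; a higher number here means a weaker inhibitor, a lower number a stronger inhibitor
Compound 2, `COc1ncnc2c1c(-c1cc3ccccc3o1)cn2[C@@H]1O[C@H](CO)[C@@H](O)[C@H]1O`: 13800 nM in this assay
Compound 3, `Nc1nc(N)c2c(-c3ccoc3)cn([C@@H]3O[C@H](CO)[C@@H](O)[C@H]3O)c2n1`: > 20000 nM in this assay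

Compound 1 gives 110 nM in this assay. Compound 2 gives 13800 nM in this assay, and the change between them is 1-benzofuran-2-yl in place of furan-3-yl on an aromatic carbon; it made a step of a 130-fold higher number from compound 1 to compound 2 (2.10 log units; beyond the scatter). For compound 3 the value > 20000 nM is a limit of this assay and not a number, a limit at which (the limit of > 20000 nM in this assay, at which 1 of the 3 values shown sits). The difference between the core of compound 1 and the core of compound 3 is not broken down here.

Compound 4, `Nc1nc(N)c2c(-c3cc4ccccc4o3)cn([C@@H]3O[C@H](CO)[C@@H](O)[C@H]3O)c2n1`, has not been measured. It differs from compound 3 by 1-benzofuran-2-yl in place of furan-3-yl on an aromatic carbon, the same kind of change as that from compound 1 to compound 2, and the place is the same word for word. Because compound 3 already sits at > 20000 nM, compound 4 is expected to give a limit again, so its estimated step that the limit leaves unreadable from compound 3 to compound 4 rests on the earlier step being a weakening. Compound 4 is expected to give about 60000 nM, within 15000 nM to 300000 nM.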

Compound 4, half-maximal inhibitory concentration: > 20000 nM
Compound 4 gave a limit, no number; the forecaster's own chance of this, stated with the estimate: 90%; the middle value is on the limit's open side.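

In this assay compound 4 gives > 20000 nM, which is a limit of the assay and not a number. Compound 3 also stands at a limit, so no step between compound 3 and compound 4 can be read: the limit of > 20000 nM in this assay, at which 2 of the 4 values shown sit.

The compounds shown leave open whether 1-benzofuran-2-yl in place of furan-3-yl changes anything on the core of compound 3.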